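Thioether aryl swaps in a pyrazole–oxadiazole series

The compounds below may be only part of what the source reports. "The series", "measured", "known", "first", "only" and "open" are said of these compounds alone.

Compound 1, `Cn1nc(-c2nnc(SCc3c(F)cccc3F)o2)cc1-c1ccc(C(F)(F)F)cc1`: 26200 nM in a functional assay on MCF7 cells (Homo sapiens) for cytotoxicity, read by MTT assay, with a stated time of 24 h; on this read-out higher numbers stand for weaker inhibition and lower numbers for stronger inhibition
Compound 2, `Cn1nc(-c2nnc(SCc3ccc(Cl)c(Cl)c3)o2)cc1-c1ccc(C(F)(F)F)cc1`: 27200 nM in this assay

Compound 2 stands highest of the two numbers, though its gap to compound 1, a 1.0-fold higher number from compound 1 to compound 2 (0.02 log units; within the scatter), is within the scatter. Compound 3, `Cn1nc(-c2nnc(SCCc3ccc(F)cc3)o2)cc1-c1ccc(C(F)(F)F)cc1`, differs from compound 2 by 4-fluorobenzyl in place of 3,4-dichlorophenyl on a saturated chain carbon bound to a sulfur. Among the measured compounds shown here, the only step that bears on this position is the one from compound 1 to compound 2, which changed the aryl group at the same place without effect. No step beyond the scatter is therefore expected in this assay, and the estimated step is a 1.0-fold lower number from compound 2 to compound 3 (0.00 log units; within the scatter). For compound 3 the expected value is 27000 nM, with a range from 12000 nM to 60000 nM.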

Compound 3, half-maximal inhibitory concentration: 25200 nM
The estimate for compound 3 lay 1.1-fold (0.03 log units) above the measured number, and the stated range covers the measured number.
By their numbers in this assay, from the lowest: compounds 3, 1 and 2 (each within the scatter of the next).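

With 2-(4-fluorophenyl)ethyl in place of 3,4-dichlorobenzyl, the read-out in this assay stays within the scatter, at a 1.1-fold lower number from compound 2 to compound 3 (0.03 log units; within the scatter) and a 1.0-fold lower number from compound 1 to compound 3 (0.02 log units; within the scatter). At this place on the saturated chain carbon bound to a sulfur, the numbers therefore separate neither the aryl substitution nor the 4-fluorobenzyl group from the earlier groups. No supporting data bear on this result. From the compounds shown here alone, an amine or a carboxylic acid at this place remains open. Also open, going by these compounds, is whether any change to the shared core would move the number in this assay.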